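Epimer of a Peroxide Ester Awaiting Growth-Inhibition Data

The source may hold more compounds than are shown below. What is called first, only, known or untested is meant among the compounds shown, and "the series" means these compounds.

Measured compounds:
compound 1 `C=C1CCCC(C)(C)C1(O)CC/C(C)=C/CC[C@]1(C)CC[C@@H]([C@@H](C)C(=O)OC)OO1`, > 5000 nM
compound 2 `C=C1CCC[C@H]2[C@](C)(CC[C@]3(C)CC[C@H]([C@@H](C)C(=O)O)OO3)[C@@H](C)CC[C@]12C`, 980 nM
compound 3 `C=C1CCCC(C)(C)C1CC[C@@]1(C)CC[C@H]([C@@H](C)C(=O)O)OO1`, 2160 nM

In a functional assay on MOLT-4 cells (Homo sapiens) for cytotoxicity, read by colony formation (on this read-out lower numbers stand for stronger inhibition of growth and higher numbers for weaker inhibition of growth), compound 1 reports only a limit, > 5000 nM, which is the boundary of the assay rather than a number; this is the limit of > 5000 nM in this assay, at which 1 of the 3 values shown sits. In this assay compound 2 gives 980 nM and compound 3 gives 2160 nM, both measured values. Compound 4 `C=C1CCCC(C)(C)C1(O)CC/C(C)=C/CC[C@]1(C)CC[C@H]([C@@H](C)C(=O)OC)OO1` is not yet measured. It differs from compound 1 as follows: the two compounds have the same atoms and bonds; at least one stereo element is drawn with a configuration in one of them and without one in the other: 1 of 5 stereo elements differ; a stereocentre at a saturated ring carbon is drawn S in compound 1 and R in compound 4. No measured pair separated by such a change exists among these compounds, so no size of step can be taken from them. Compound 4 is expected at 6000 nM, between 2000 nM and 20000 nM. The expected step that the limit leaves unreadable from compound 1 to compound 4 is small, not clearly beyond the scatter.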

Compound 4, concentration for 50% growth inhibition: > 5000 nM
Compound 4: only a limit was reported; the forecaster's own chance of this, stated with the estimate: 55%; the middle value is on the limit's open side.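

Compound 1 and compound 4 both stand at a limit in this assay and so no step can be read from one to the other: the limit of > 5000 nM in this assay, at which 2 of the 4 values shown sit. On these data alone, whether the stereocentre drawn S in compound 1 and R in compound 4 changes the read-out in this assay remains open.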